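The source may hold more compounds than are shown below. What is called first, only, known or untested is meant among the compounds shown, and "the series" means these compounds.

Measured so far: compound 1 `CC(C(=O)NCc1ccc(C(F)(F)F)nc1NCc1cccnc1)c1ccc(NS(C)(=O)=O)c(F)c1` gives "not active" (no number reported); compound 2 `CC(C(=O)NCc1ccc(C(F)(F)F)nc1N1CCC(Cc2ccc(F)c(F)c2)CC1)c1ccc(NS(C)(=O)=O)c(F)c1` gives 0.2 nM; compound 3 `CC(C(=O)NCc1ccc(C(F)(F)F)nc1N1CCC(=O)CC1)c1ccc(NS(C)(=O)=O)c(F)c1` gives 91 nM.

These are readings in a functional assay on CHO-K1 cells for antagonist activity at transient receptor potential cation channel subfamily V member 1 (Homo sapiens), read by FLIPR; a lower number here means a stronger inhibitor, a higher number a weaker inhibitor. Compound 1 stands without a number in this assay, reported only as not active, so it gives no fixed starting point. Compound 4 `CC(C(=O)NCc1ccc(C(F)(F)F)nc1N1CCC(CN(C)C)CC1)c1ccc(NS(C)(=O)=O)c(F)c1` differs from compound 1 as follows: 4-((dimethylamino)methyl)piperidin-1-yl in place of ((pyridin-3-yl)methyl)amino on an aromatic carbon. Among the compounds with values here, no measured pair shows this exact step, so the direction can only be guessed from the other two compounds, which both carry a piperidin-1-yl group at the same place and give numbers in this assay, compound 2 the lower and compound 3 the higher. Compound 4 is therefore expected to give a number rather than an inactive call, and its estimated value is 300 nM, within a range of 30 nM to 3000 nM.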

Compound 4, inhibition constant: 2.1 nM
Compound 4: the middle estimate sits 140-fold (2.15 log units) above what was measured; the measured number lies below the stated range.
By their numbers in this assay, from the lowest: compound 2; then compound 4; then compound 3.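

In this assay, 4-((dimethylamino)methyl)piperidin-1-yl in place of 4-oxopiperidin-1-yl gives a 43-fold lower number from compound 3 to compound 4 (1.64 log units; beyond the scatter), so this position takes a piperidin-1-yl group carrying a dimethylamino chain and still gives a low number. Dimethylamino in place of 3,4-difluorophenyl gives an 11-fold higher number from compound 2 to compound 4 (1.02 log units; beyond the scatter), so the aromatic end of compound 2 is not required for a low number, although compound 2 remains the lower of the two. Nothing measured here explains either step. From the compounds shown here alone, whether a carboxylic acid or a morpholin-4-yl group in place of dimethylamino would keep the number low remains open, as does the reading with a longer chain.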